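This account rests on a few compounds, and the source may have more. Where it says the series, first, only, none or still open, it means among the compounds named here.

Compound 1 `CC(C)(C)C1=CC(=O)C=C(NCC(=O)O)C1=O` carries a carboxymethyl group on its amine nitrogen. In a functional assay on Fem-X cells (Homo sapiens) for cytotoxicity, read by MTT assay, with a stated time of 72 h (a lower number here means a stronger inhibitor, a higher number a weaker inhibitor), compound 1 gives 34300 nM. Compound 3 `CC(C)[C@@H](NC1=CC(=O)C=C(C(C)(C)C)C1=O)C(=O)O` keeps the core of compound 1 and differs only by isopropyl in place of hydrogen on a saturated chain carbon bound to an amine nitrogen and a carbonyl carbon. In this assay compound 3 gives 24600 nM, so the change produced a 1.4-fold lower number from compound 1 to compound 3 (0.14 log units; within the scatter).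

Compound 2 `CC1=CCC[C@H]2[C@](C)(CC3=CC(=O)C=C(NCC(=O)O)C3=O)[C@@H](C)CC[C@]12C` has a different core, and the difference between the two cores is not broken down here. In this assay compound 2 gives 17800 nM. Compound 4 `CC1=CCC[C@H]2[C@](C)(CC3=CC(=O)C=C(N[C@@H](C(=O)O)C(C)C)C3=O)[C@@H](C)CC[C@]12C` is compound 2 with isopropyl in place of hydrogen on a saturated chain carbon bound to an amine nitrogen and a carbonyl carbon, the same change that separates compound 1 from compound 3, made on the same place. Compound 4 has not yet been measured in this assay.

Because the earlier example of this change gave a 1.4-fold lower number from compound 1 to compound 3 (0.14 log units; within the scatter), the step expected from compound 2 to compound 4 is of a similar small size, a 1.4-fold lower number from compound 2 to compound 4 (0.14 log units; within the scatter), which rests on one pair only. Compound 4 is therefore estimated to give about 13000 nM in this assay, with a likely range from 6000 nM to 30000 nM.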

Compound 4, half-maximal inhibitory concentration: 11400 nM
Beside the measured number, compound 4's estimate is 1.1-fold (0.06 log units) above it, and the stated range covers the measured number.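

Putting isopropyl in place of hydrogen on a saturated chain carbon bound to an amine nitrogen and a carbonyl carbon gave a 1.6-fold lower number from compound 2 to compound 4 (0.19 log units; within the scatter) in this assay, a small step on this core as well. Set beside the earlier example, the change looks the same on both cores: the same change on two cores in this assay, a 1.4-fold lower number (0.14 log units; within the scatter) from compound 1 to compound 3 and a 1.6-fold lower number (0.19 log units; within the scatter) from compound 2 to compound 4, 1.1-fold (0.05 log units) apart, within the scatter of two such steps. This shows that the swap from carboxymethyl to 1-carboxy-2-methylpropyl carried over between these two cores with no step beyond the scatter, but both steps lie within the scatter, so it does not show that isopropyl truly shifts the number, and two pairs cannot speak for other cores.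

The compounds shown leave open whether another group on that same chain carbon, such as a methyl, a benzyl or a longer chain, would move the number beyond the scatter. They also leave open what happens on either core when an ester or an amide stands in place of the carboxylic acid.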